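Swapping a Fluorophenyl for Trifluoromethoxy

The source may hold more compounds than are shown below. What is called first, only, known or untested is meant among the compounds shown, and "the series" means these compounds.

Measured so far:
Compound 1, `Cc1n[nH]c(C(=O)O)c1Cc1cccc(C(F)(F)F)c1`, in an assay on isolated protein for inhibition of 2-Hydroxyacid oxidase 2 (Homo sapiens), tested at 10 uM (on this read-out higher numbers stand for a stronger effect at the one concentration tested and lower numbers for a weaker effect), gives 23%.
Compound 2, `Cc1n[nH]c(C(=O)O)c1Cc1cccc(-c2ccccc2F)c1`, in this assay gives 22%.

On the numbers shown, compound 2 sits level with compound 1: the step of a number 1 percentage points lower from compound 1 to compound 2 (within the scatter) is within the scatter, so the two cannot be told apart on this read-out. Compound 3, `Cc1n[nH]c(C(=O)O)c1Cc1cccc(OC(F)(F)F)c1`, has not yet been measured. It differs from compound 2 in one place: trifluoromethoxy in place of 2-fluorophenyl on an aromatic carbon. Among the measured compounds shown here, the only measured step that bears on this change is a number 1 percentage points lower from compound 1 to compound 2 (within the scatter), where the 2-fluorophenyl of compound 2 replaced the trifluoromethyl of compound 1 without moving the number beyond the scatter. Compound 3 now carries trifluoromethoxy, a group that, like trifluoromethyl, has no ring, at the same place. For the measured compounds named here, with only one step to go on, and that one flat, the expectation for compound 3 is a step of no change at the digits printed from compound 2 to compound 3 (within the scatter), that is, nothing beyond the scatter in either direction. Compound 3 is therefore estimated at 22%, with a range from 8% to 38%.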

Compound 3, a percentage reported as inhibition, at one concentration (the size of the read-out at that concentration, not a potency): 26%
Beside the measured number, compound 3's estimate is 4 percentage points below it; the measured number falls inside the stated range.
By their numbers in this assay, from the lowest: compounds 2, 1 and 3 (each within the scatter of the next).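

In this assay, trifluoromethoxy in place of 2-fluorophenyl gives a number 4 percentage points higher from compound 2 to compound 3 (within the scatter) and trifluoromethoxy in place of trifluoromethyl gives a number 3 percentage points higher from compound 1 to compound 3 (within the scatter) and so neither change can be told apart from no change at all. This position on the aromatic ring, meta to a large group, has now carried three different groups: 2-fluorophenyl with its ring, and trifluoromethyl and trifluoromethoxy without one, the last bringing an oxygen and a hydrogen-bond acceptor that 2-fluorophenyl does not have, and the read-out at the one concentration tested stays level across all three. No accompanying measurement speaks to what lies behind this flat result.

As far as these compounds go, whether a different kind of group at this place, such as an amine, a hydroxyl or a longer alkyl chain, would move the number beyond the scatter remains open. Also open, from the compounds shown here alone, is whether a change elsewhere on the shared core, such as an amide in place of the carboxylic acid, would have a larger effect than any change seen at this position.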